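Swapping chloro for ethoxy on the shared core

A few compounds are considered here, and "the series" means these few. Any claim that something is new, unique, unknown or untested is made for them only; others in the source may bear on it.

- compound 1 `C=C1C(=O)[C@]23C[C@@]1(Cl)CC[C@H]2[C@@]12C=CC(=O)[C@](C)(C(=O)O1)[C@H]2[C@@H]3C(=O)OC`: 39800 nM
- compound 2 `C=C1C(=O)[C@]23C[C@@]1(Cl)CC[C@H]2[C@@]12C=CC(=O)[C@](C)(C(=O)O1)[C@H]2[C@@H]3C(=O)OCc1ccccc1`: 17900 nM
- compound 3 `C=C1C(=O)[C@]23C[C@@]1(I)CC[C@H]2[C@@]12C=CC(=O)[C@](C)(C(=O)O1)[C@H]2[C@@H]3C(=O)OCc1ccccc1`: 69500 nM

These values come from a functional assay on HepG2 cells (Homo sapiens) for cytotoxicity, read by MTT assay; on this read-out lower numbers stand for stronger inhibition and higher numbers for weaker inhibition. Compound 1 cannot be told apart from compound 3, while compound 2 stands clear of it, as a 2.2-fold lower number from compound 1 to compound 2 (0.35 log units; beyond the scatter) shows. Compound 4 `C=C1C(=O)[C@]23C[C@@]1(OCC)CC[C@H]2[C@@]12C=CC(=O)[C@](C)(C(=O)O1)[C@H]2[C@@H]3C(=O)OC` carries ethoxy in place of chloro on a saturated ring carbon. The closest measured change is iodo in place of chloro at that same carbon, a 3.9-fold higher number from compound 2 to compound 3 (0.59 log units; beyond the scatter), a modest step. The step of a 2.2-fold lower number from compound 1 to compound 2 (0.35 log units; beyond the scatter) lies elsewhere on the molecule, so it says little here. Among the measured compounds shown here, no ethoxy compound has been measured, so only a small upward move is expected. The estimated step is a 1.3-fold higher number from compound 1 to compound 4 (0.10 log units; within the scatter). Compound 4 is expected at 50000 nM, within an estimated range of 20000 nM to 120000 nM.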

Compound 4, half-maximal inhibitory concentration: 120000 nM
The estimate for compound 4 lay 2.4-fold (0.38 log units) below the measured number; the range from low to high includes it.
By their numbers in this assay, from the lowest: compound 2; then compounds 1, 3 and 4 (each within the scatter of the next, the first and the last beyond it).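

In this assay, ethoxy in place of chloro on this saturated ring carbon gives weaker inhibition, as a 3.0-fold higher number from compound 1 to compound 4 (0.48 log units; beyond the scatter) shows. Iodo in place of chloro at the same carbon also raised the number, a 3.9-fold higher number from compound 2 to compound 3 (0.59 log units; beyond the scatter), so both replacements shown for chloro weaken inhibition, and no compound here goes against that. No available evidence explains this loss.

From the compounds shown here alone, it remains open whether an amine or a hydroxyl group at this carbon would also give a higher number. Going by these compounds, it is also open whether ethoxy would have the same effect on compound 2, which carries the added phenyl group.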